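Swapping Pyrimidin-2-yl for 6-Methylpyridin-2-yl on the Shared Core

This account rests on a few compounds, and the source may have more. Where it says the series, first, only, none or still open, it means among the compounds named here.

Measured compounds:
compound 1, `N#Cc1cccnc1N1CCN(Cc2nc3ccccc3[nH]2)CC1`, 50%
compound 2, `c1cnc(N2CCN(Cc3nc4ccccc4[nH]3)CC2)nc1`, 49%

In an assay on HEK293 cells with D(4) dopamine receptor (Homo sapiens) as the target, read by FLIPR (on this read-out higher numbers stand for larger maximal responses and lower numbers for smaller maximal responses), compound 1 gives 50% and compound 2 gives 49%. Within the data shown here, the only step known so far, a number 1 percentage points lower from compound 1 to compound 2 (within the scatter), shows that exchanging the aromatic group on the amine nitrogen in a ring left the maximal response essentially unchanged. Among the measured compounds shown here, on the two numbers known, compound 2 stands as the lower of the two, yet its gap to compound 1 lies within the scatter, so the two cannot be ordered.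

Compound 3, `Cc1cccc(N2CCN(Cc3nc4ccccc4[nH]3)CC2)n1`, is not yet measured. It differs from compound 2 by 6-methylpyridin-2-yl in place of pyrimidin-2-yl on an amine nitrogen in a ring. For the measured compounds named here, the only step that bears on this change is a number 1 percentage points lower from compound 1 to compound 2 (within the scatter), in which a different six-membered aromatic group at the same place was traded without a step beyond the scatter. The account therefore expects no step beyond the scatter in this assay for compound 3 either, that is, an expected change of a number 1 percentage points higher from compound 2 to compound 3 (within the scatter). Compound 3 is estimated to give 50%, within a range from 35% to 65%.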

Compound 3, largest response reached (reported as efficacy), in percent of the reference or control that the assay uses: 36%
For compound 3 the middle estimate is 14 percentage points above the measured one; the measured number falls inside the stated range.
By their numbers in this assay, from the lowest: compound 3; then compounds 2 and 1 (each within the scatter of the next).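

In this assay, the group on the amine nitrogen in a ring turns out to matter, which the earlier pair could not show: 6-methylpyridin-2-yl in place of pyrimidin-2-yl gives a number 13 percentage points lower from compound 2 to compound 3 (beyond the scatter) and in place of 3-cyanopyridin-2-yl gives a number 14 percentage points lower from compound 1 to compound 3 (beyond the scatter) in the same read-out. The position is therefore not indifferent to a six-membered aromatic group, although the earlier exchange, a number 1 percentage points lower from compound 1 to compound 2 (within the scatter) on its own, had left that impression. The number of ring hetero atoms does not sort the three compounds, since the pyridine ring of compound 1 stays within the scatter of the pyrimidine ring of compound 2, and only the 6-methylpyridin-2-yl group of compound 3 stands apart.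

Still open, on these data alone, is whether the step belongs to the methyl group or to the ring that carries it, and a plain pyridin-2-yl or a phenyl group at this place would be needed to tell these apart. Nothing given here offers any measurement that explains the step.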